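This account rests on a few compounds, and the source may have more. Where it says the series, first, only, none or still open, it means among the compounds named here.

Compound 1 `Cc1cnn(C(=O)N2CCCCC2)c1`: > 100000 nM
Compound 2 `Cc1cnn(C(=O)N(C)CCN(C)Cc2cccc(OCc3ccccc3)c2)c1`: > 100000 nM
Compound 3 `Cc1cnn(C(=O)N2CCN(C(c3ccc4ccccc4c3)c3ccc4ccccc4c3)CC2)c1`: > 100000 nM

In an assay on membranes from brain for binding affinity to neutral cholesterol ester hydrolase 1 (Mus musculus), read by fluorescence, with stated times of 1 h and 30 min (on this read-out lower numbers stand for stronger inhibition and higher numbers for weaker inhibition), compound 1 reaches only the limit of the assay, > 100000 nM. Compound 2 likewise sits at the limit, > 100000 nM. Compound 3 also stands at the limit, > 100000 nM, a boundary of the assay rather than a number. All three results sit at the limit of > 100000 nM in this assay, at which 3 of the 3 values shown sit. Compound 4 `N#Cc1cnn(C(=O)N2CCN(C(c3ccc4ccccc4c3)c3ccc4ccccc4c3)CC2)c1` differs from compound 3 by cyano in place of methyl on an aromatic carbon. Within the data shown here, no step between measured compounds exists, so nothing shows how such a change moves this assay. Among the measured compounds shown here, with every measured compound at the limit, compound 4 is expected to stay close to it, and the estimated step of an at least 1.6-fold lower number from compound 3 to compound 4 (0.22 log units; that floor lies within the scatter) rests on no measured step. For compound 4 the expected value is 60000 nM, within a range from 5000 nM to 100000 nM.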

Compound 4, half-maximal inhibitory concentration: > 100000 nM
Compound 4 gave a limit, no number; the forecaster's own chance of this, stated with the estimate: 70%; at least 1.6-fold (0.22 log units) between middle value and limit.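

Among these compounds, compound 3 and compound 4 both stop at a limit rather than a number, so no step between them can be read: the limit of > 100000 nM in this assay, at which 4 of the 4 values shown sit. In this assay the compounds shown leave open which structural change, if any, would give a measurable value.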